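Dimethylating the Thioamide End of Compound 3

The source may report more compounds than this note shows. Statements on the series, on what has been measured and on what is new or still open speak of the compounds shown alone.

Of the compounds shown here, three sharing one core have been measured in a functional assay on the whole organism (stomach) with Rattus norvegicus as the target; on this read-out lower numbers stand for an effect already at smaller amounts and higher numbers for an effect only at larger amounts of compound. Compound 1 `C/N=C(\S)CCn1nc(-c2ccccc2)ccc1=O` gives 58.5 mg/kg. Compound 2 `CC/N=C(\S)CCn1nc(-c2ccccc2)ccc1=O` gives 100 mg/kg. Compound 3 `N=C(S)CCCCCn1nc(-c2ccccc2)ccc1=O` gives 23.3 mg/kg, the lowest of the three numbers: the step of a 2.5-fold lower number from compound 1 to compound 3 (0.40 log units; beyond the scatter) and the step of a 4.3-fold lower number from compound 2 to compound 3 (0.63 log units; beyond the scatter) both lie beyond the scatter, so compound 3 acts at the smallest dose among the measured compounds.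

Compound 4 `CN(C)C(=S)CCCCCn1nc(-c2ccccc2)ccc1=O` has not yet been measured. It differs from compound 3 in this way: a group of 5 heavy atoms (3 carbon, 1 nitrogen, 1 sulfur; no ring) in place of a group of 3 heavy atoms (1 carbon, 1 nitrogen, 1 sulfur; no ring), on a saturated chain carbon, five bonds along the chain from an aromatic nitrogen. The change puts carbon onto the nitrogen of the end group and removes its hydrogen-bond donors, leaving the chain and the sulfur as they were. The nearest guide among the measured steps is a 1.7-fold higher number from compound 1 to compound 2 (0.23 log units; within the scatter), where a methyl was likewise added close to a double-bonded nitrogen, and that step stayed within the scatter. The two steps ending at compound 3 changed chain length and end group at once, so they say little about this smaller change. The expected step of a 1.4-fold higher number from compound 3 to compound 4 (0.14 log units; within the scatter) is therefore none beyond the scatter, perhaps a slightly higher number. Compound 4 is estimated at 32 mg/kg, with a range from 13 mg/kg to 80 mg/kg.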

Compound 4, dose for half-maximal effect: 100 mg/kg
Compound 4: the middle estimate sits 3.1-fold (0.49 log units) below what was measured; measured number outside the range, above it.
By their numbers in this assay, from the lowest: compound 3; then compounds 1, 2 and 4 (each within the scatter of the next).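

In this assay, the step of a 4.3-fold higher number from compound 3 to compound 4 (0.63 log units; beyond the scatter) lies beyond the scatter, so at this position, five bonds along the chain from an aromatic nitrogen, the end group's substitution makes a readable difference. The earlier step of a 1.7-fold higher number from compound 1 to compound 2 (0.23 log units; within the scatter) stayed within the scatter, but it lengthened a substituent already on the nitrogen of a shorter chain, whereas here carbon replaces the hydrogens on the nitrogen of compound 3, and the end group goes from 2 hydrogen-bond donors to 0 with its 1 hydrogen-bond acceptor unchanged. No evidence is available on what lies behind this rise.

The compounds shown change the two hydrogens on that nitrogen together, so they cannot separate the effect of adding carbon from that of losing every donor, and a thioamide end carrying a single methyl on the nitrogen would be the direct test of that question. They also leave open whether the sulfur matters at this chain end, which an amide with oxygen in place of the sulfur, or a carboxylic acid, would address on the same chain.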